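This account rests on a few compounds, and the source may have more. Where it says the series, first, only, none or still open, it means among the compounds named here.

Compound 2 `CC(=O)OC[C@H]1O[C@@H](n2cc(CN3C(=O)/C(=C/c4cccs4)c4ccccc43)nn2)[C@H](OC(C)=O)[C@@H](OC(C)=O)[C@@H]1OC(C)=O` carries a thiophen-2-yl group on a double-bonded chain carbon bound to a double-bonded ring carbon. In a functional assay on A549 cells (Homo sapiens) for cytotoxicity, read by sulforhodamine B assay, with a stated time of 48 h (a lower number here means a stronger inhibitor, a higher number a weaker inhibitor), compound 2 gives 20800 nM, the lowest of the two numbers recorded, and its nearest neighbour is compound 1 `CC(=O)OC[C@H]1O[C@@H](n2cc(CN3C(=O)/C(=C/c4ccc5ccccc5c4)c4ccccc43)nn2)[C@H](OC(C)=O)[C@@H](OC(C)=O)[C@@H]1OC(C)=O`, which in this assay gives 30900 nM; the step of a 1.5-fold lower number from compound 1 to compound 2 (0.17 log units; within the scatter) lies within the scatter, so the two compounds cannot be ordered. Compound 3 `CCC/C=C1/C(=O)N(Cc2cn([C@@H]3O[C@H](COC(C)=O)[C@@H](OC(C)=O)[C@H](OC(C)=O)[C@H]3OC(C)=O)nn2)c2ccccc21` has not yet been measured. It differs from compound 2 in one place: propyl in place of thiophen-2-yl on a double-bonded chain carbon bound to a double-bonded ring carbon. Within the data shown here, the only measured step at this position, a 1.5-fold lower number from compound 1 to compound 2 (0.17 log units; within the scatter), swapped one aromatic ring for another and hardly moved the number. Among the measured compounds shown here, no measured step replaces a ring with a chain here, so the entry of propyl lacks a direct precedent. Because a 1.5-fold lower number from compound 1 to compound 2 (0.17 log units; within the scatter) stayed within the scatter, the expected step is a 1.4-fold higher number from compound 2 to compound 3 (0.16 log units; within the scatter), without a direction that can be trusted beyond the scatter. Compound 3 is therefore estimated at 30000 nM in this assay, with a range from 10000 nM to 100000 nM.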

Compound 3, half-maximal inhibitory concentration: 24100 nM
For compound 3 the middle estimate is 1.2-fold (0.10 log units) above the measured one; the measured number falls inside the stated range.
By their numbers in this assay, from the lowest: compounds 2, 3 and 1 (each within the scatter of the next).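

In this assay, the change from an aromatic ring to an open chain on a double-bonded chain carbon bound to a double-bonded ring carbon, with propyl in place of thiophen-2-yl, gives a 1.2-fold higher number from compound 2 to compound 3 (0.06 log units; within the scatter). The same holds for propyl in place of naphthalen-2-yl, which gives a 1.3-fold lower number from compound 1 to compound 3 (0.11 log units; within the scatter), so none of the three compounds can be ordered against another. Among these compounds, until now the only comparison at this place had exchanged one aromatic ring for another, whereas these steps show that, across these three compounds, the number stays within the scatter even when the group entering has no ring and no hydrogen-bond acceptor, and so a ring at this place is not required to keep it there.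

Going by these compounds, whether a group of a different kind at this place, such as an amine, a carboxylic acid or a longer chain, would move the number beyond the scatter remains open, as does whether the same picture would hold away from the acetylated sugar carried by all three compounds. Nothing available here offers an explanation for how little these numbers differ.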